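Taking the Sulfonamide Arm Off Compound 3

A few compounds are considered here, and "the series" means these few. Any claim that something is new, unique, unknown or untested is made for them only; others in the source may bear on it.

Of the compounds shown here, three built on one shared core have been tested in an ADME assay on HFF cells (Homo sapiens) for cytotoxicity, read by MTT assay, with a stated time of 72 h; a higher number here means a weaker inhibitor, a lower number a stronger inhibitor. Compound 1 `O=C1O[C@H]([C@@H](O)Cn2cc(-c3cccc(O)c3)nn2)C(OCc2ccccc2)=C1OCc1ccccc1` gives 39000 nM. Compound 2 `O=C1O[C@H]([C@@H](O)Cn2cc(C3CC3)nn2)C(OCc2ccccc2)=C1OCc1ccccc1` gives 24300 nM, and the step of a 1.6-fold lower number from compound 1 to compound 2 (0.21 log units; within the scatter) shows that exchanging those two groups on the five-membered ring changes little. Compound 3 `O=C1O[C@H]([C@@H](O)Cn2cc(CNS(=O)(=O)c3ccc(Cl)cc3)nn2)C(OCc2ccccc2)=C1OCc1ccccc1` gives 20 nM, the lowest of the three numbers by a wide margin: the steps of a 2000-fold lower number from compound 1 to compound 3 (3.29 log units; beyond the scatter) and a 1200-fold lower number from compound 2 to compound 3 (3.08 log units; beyond the scatter) are both large and well beyond the scatter, so compound 3 is clearly the strongest inhibitor of the three.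

Compound 4 `O=C1O[C@H]([C@@H](O)Cn2ccnn2)C(OCc2ccccc2)=C1OCc1ccccc1` is compound 3 with that arm removed: hydrogen in place of (((4-chlorophenyl)sulfonyl)amino)methyl on an aromatic carbon. The two steps leading into compound 3 are the ones that bear on this change, since each of them shows what happens when this group is present rather than a small group. Undoing it is therefore expected to reverse that effect, with the number in this assay expected to climb back toward the region where compound 1 and compound 2 sit, a step of roughly a 1500-fold higher number from compound 3 to compound 4 (3.18 log units; beyond the scatter). Compound 4 is estimated at 30000 nM, with a likely range from 8000 nM to 100000 nM.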

Compound 4, half-maximal inhibitory concentration: 610 nM
Estimate against measurement, compound 4: 49-fold (1.69 log units) above, and the stated range ends above it.
By their numbers in this assay, from the lowest: compound 3; then compound 4; then compounds 2 and 1 (each within the scatter of the next).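

In this assay, a bare hydrogen on this aromatic carbon does not behave like the two small-to-medium groups tried earlier: the change shows up as a 40-fold lower number from compound 2 to compound 4 (1.60 log units; beyond the scatter) and as a 64-fold lower number from compound 1 to compound 4 (1.81 log units; beyond the scatter), so cyclopropyl and 3-hydroxyphenyl both sit well above hydrogen here. The (((4-chlorophenyl)sulfonyl)amino)methyl arm still gives a lower number than hydrogen, as the reverse change shows, with a 31-fold higher number from compound 3 to compound 4 (1.48 log units; beyond the scatter), but that step is smaller than the gaps seen among the first three compounds, so the position can move the number in either direction from hydrogen. Nothing available explains why the numbers fall in this order.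

As far as these compounds go, what remains open is which part of the arm goes with the lower number: a plain aminomethyl group, the same arm with an unsubstituted phenyl ring in place of the 4-chlorophenyl, or an amide in place of the sulfonamide would begin to separate its pieces. A methyl or ethyl group at this position would also show whether very small groups stay close to hydrogen or move toward cyclopropyl.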